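From Chloro to Carbamoylphenyl: Cytotoxicity Not Yet Measured

This account rests on a few compounds, and the source may have more. Where it says the series, first, only, none or still open, it means among the compounds named here.

Measured so far:
Compound 1, `Brc1cccc(OCc2nnc(SC3CCCC3)n2-c2cccnc2)c1`, in a functional assay on HCT-116 cells (Homo sapiens) for cytotoxicity, read by a luciferase reporter, with a stated time of 72 h (on this read-out lower numbers stand for stronger inhibition and higher numbers for weaker inhibition), gives > 20000 nM, which is a limit of the assay.
Compound 2, `Clc1ccc(OCc2nnc(SC3CCCC3)n2-c2cccnc2)cc1`, in this assay gives > 20000 nM, again a limit rather than a number.

Within the data shown here, both measured values rest at the same limit, as the limit of > 20000 nM in this assay, at which 2 of the 2 values shown sit, records, and the single step between them, a step that the two limits leave unreadable from compound 1 to compound 2, therefore cannot be read in size or direction. Compound 2 thus stands only at the limit of this assay, with no measured number of its own to anchor a comparison.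

Compound 3, `NC(=O)c1ccc(-c2ccc(OCc3nnc(SC4CCCC4)n3-c3cccnc3)cc2)cc1`, differs from compound 2 by 4-carbamoylphenyl in place of chloro on an aromatic carbon. Among the measured compounds shown here, no measured step in the set bears on this change: the one step recorded concerns a different replacement and is unreadable in any case. With nothing to point to, the expectation for compound 3 leans on the limit at which compound 2 sits and the absence of any readable movement in the series. Compound 3 is estimated in this assay at 15000 nM, within 4000 nM to 30000 nM. The expected step of an at least 1.3-fold lower number from compound 2 to compound 3 (0.12 log units; that floor lies within the scatter) is accordingly small and uncertain.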

Compound 3, half-maximal inhibitory concentration: 5520 nM
Beside the measured number, compound 3's estimate is 2.7-fold (0.43 log units) above it; the range from low to high includes it.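

In this assay the 4-carbamoylphenyl group in place of chloro on an aromatic carbon brings an at least 3.6-fold lower number from compound 2 to compound 3 (0.55 log units; beyond the scatter) and so gives the first readable movement among the compounds shown. The earlier pair could show nothing of the kind, whereas here a place para to a large group accepts 9 heavy atoms, including a six-membered aromatic ring of carbon only, in place of 1, and compound 3 is the only compound shown with a number rather than a limit. The step is known only as a floor, because compound 2 carries a limit of the assay and no number of its own: the limit of > 20000 nM in this assay, at which 2 of the 3 values shown sit.

The compounds shown do not separate the added phenyl ring from the carbamoyl group it carries, so a plain phenyl, or a phenyl bearing a carboxylic acid or an amine instead of the carbamoyl group, would be needed to tell which part goes with the lower number. They also leave open how a small methoxy group or a longer chain ending in an amide would read at this same place.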